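Shrinking a Hydroxycycloalkyl Ring at the Sigma Receptor

The source may report more compounds than this note shows. Statements on the series, on what has been measured and on what is new or still open speak of the compounds shown alone.

Of the compounds shown here, two have been measured so far, sharing one core and differing only in where the bromine sits on the phenyl ring. Compound 1 `O[C@H]1CCCC[C@@H]1N1CCN(CCCc2cccc(Br)c2)CC1` in an assay on membranes from cerebrum (strain Sprague-Dawley) for displacement of a labelled ligand from Sigma non-opioid intracellular receptor 1 (Rattus norvegicus), read by scintillation counting, with a stated time of 90 min (on this read-out higher numbers stand for weaker inhibition and lower numbers for stronger inhibition), gives 7.7 nM. Compound 2 `O[C@H]1CCCC[C@@H]1N1CCN(CCCc2ccc(Br)cc2)CC1` in this assay gives 4.4 nM. The step of a 1.8-fold lower number from compound 1 to compound 2 (0.24 log units; within the scatter) leaves the two within the scatter, so compound 2 holds the lower of the two numbers without standing apart from compound 1.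

Compound 3 `O[C@H]1CCC[C@@H]1N1CCN(CCCc2ccc(Br)cc2)CC1` is not yet measured. It differs from compound 2 by 2-hydroxycyclopentyl in place of 2-hydroxycyclohexyl on an amine nitrogen in a ring. Going by the values given here, no measured step touches this part of the molecule: the one known step, from compound 1 to compound 2, concerns the bromophenyl group and is itself within the scatter. There is therefore no measured guide to the size or direction of the change from a six-membered to a five-membered hydroxy-bearing ring, and the expectation is a step no larger than the scatter. In this assay the expected number for compound 3 is 5.5 nM, within 2 nM to 16 nM. That amounts to an expected step of a 1.3-fold higher number from compound 2 to compound 3 (0.10 log units; within the scatter).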

Compound 3, inhibition constant: 8.1 nM
Estimate against measurement, compound 3: 1.5-fold (0.17 log units) below; measured number inside the range.
By their numbers in this assay, from the lowest: compounds 2, 1 and 3 (each within the scatter of the next).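

Going by these compounds alone, this is the first measured change at the hydroxy-bearing ring on the amine nitrogen, and in this assay putting 2-hydroxycyclopentyl in place of 2-hydroxycyclohexyl gives a 1.8-fold higher number from compound 2 to compound 3 (0.27 log units; within the scatter) and so stays within the usual variation between repeated measurements. The swap keeps the hydrogen-bond donor, the hydrogen-bond acceptor and both defined stereocentres, and only the ring size differs, so on this read-out the five-membered ring cannot be told apart from the six-membered one at this position. No other kind of measurement is at hand to interpret this result.

Both rings shown carry a hydroxyl group, so the compounds leave open what happens at this position when an amine or a methoxy group stands in its place, or when the ring is dropped for a plain cyclohexyl group. Going by these compounds, a single step between two ring sizes also gives no trend, so it remains open whether a larger ring such as 2-hydroxycycloheptyl or a smaller one such as 2-hydroxycyclobutyl would move the number beyond that variation.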